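The compounds below may be only part of what the source reports. "The series", "measured", "known", "first", "only" and "open" are said of these compounds alone.

Three analogues of the shared core have been tested in an ADME assay on WI-38 cells (Homo sapiens) for cytotoxicity, read by MTT assay, with a stated time of 72 h (on this read-out higher numbers stand for weaker inhibition and lower numbers for stronger inhibition), so far. Compound 1 `CC(C)(C)NC(=O)CCc1cccc2c1B(O)OC2` carries the amide on tert-butyl; in this assay compound 1 gives only a limit, > 100000 nM. Compound 2 `CC(C)(C)OC(=O)Nc1ccc(NC(=O)CCc2cccc3c2B(O)OC3)cc1` likewise returns a limit in this assay, > 100000 nM. Compound 3 `CCOC(=O)c1ccc(NC(=O)CCc2cccc3c2B(O)OC3)cc1` also comes back as a limit in this assay, > 100000 nM. For the measured compounds named here, the single measured step, a step that the two limits leave unreadable from compound 2 to compound 3, therefore has no readable size. Going by the values given here, all three values sit at the limit of > 100000 nM in this assay, at which 3 of the 3 values shown sit, so nothing so far separates one compound from another on cytotoxicity.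

Compound 4 `O=C(CCc1cccc2c1B(O)OC2)Nc1cccc(I)c1` is the next compound to be measured. It differs from compound 1 by 3-iodophenyl in place of tert-butyl on an amide-type nitrogen. Among the compounds with values here, no measured step covers this change; the only step available, between compound 2 and compound 3, concerns an aromatic carbon and is unreadable. With every measured compound at the limit, no direction can be read from the data, and a step in this assay is expected to be none beyond the scatter, most probably reported again as a limit. Compound 4 is thus expected to give 100000 nM in this assay, within 30000 nM to 300000 nM. The expected step, a number no higher from compound 1 to compound 4 (the limit leaves the size open), is estimated to be flat.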

Compound 4, half-maximal inhibitory concentration: 71000 nM
Estimate against measurement, compound 4: 1.4-fold (0.15 log units) above, and the stated range covers the measured number.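

In this assay, for the compounds shown here, compound 4 gives 71000 nM, the first value that is a number and not a limit. This shows that a compound with the shared core can give a finite reading in this assay, and that the amide-type nitrogen is a place where such a reading appears when it carries 3-iodophenyl. Going by these compounds, the change of tert-butyl to 3-iodophenyl gives an at least 1.4-fold lower number from compound 1 to compound 4 (0.14 log units; that floor lies within the scatter), so the only size that can be stated stays within the scatter, and the true size stays open with compound 1 at a limit; the other values offer no finite number for comparison: the limit of > 100000 nM in this assay, at which 3 of the 4 values shown sit.

Open, on these data alone, is how a plain phenyl, a 3-chlorophenyl or a 3-aminophenyl on the same amide-type nitrogen would read in this assay, which would separate the part played by the aromatic ring from that of the iodine. Going by these compounds alone, also open is how a carboxylic acid in place of the ethyl ester of compound 3 would read, and no step among the compounds at the limit can be read.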